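The source may hold more compounds than are shown below. What is called first, only, known or untested is meant among the compounds shown, and "the series" means these compounds.

Working notes on the series. Three compounds sharing a core have numbers in an assay on isolated protein for binding affinity to cysteinyl leukotriene receptor 1 (Cavia porcellus); on this read-out higher numbers stand for weaker inhibition and lower numbers for stronger inhibition. Compound 1 `c1cc(OCc2ccc(Cc3nnn[nH]3)cc2)cc(OCc2ccc3ccccc3n2)c1` gives 7.3 nM in this assay. Compound 2 `c1cc(OCc2ccc3ccccc3n2)cc(OCc2ccccc2Cc2nnn[nH]2)c1` gives 12 nM in this assay. Compound 3 `c1cc(COc2ccc(-c3nn[nH]n3)cc2)cc(OCc2ccc3ccccc3n2)c1` gives 2.9 nM in this assay, the lowest of the three numbers; its gaps to compound 1 and to compound 2 both lie beyond the usual scatter, so compound 3 stands as the strongest binder measured so far.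

Compound 4 `COc1cc(-c2nn[nH]n2)ccc1OCc1cccc(OCc2ccc3ccccc3n2)c1` has not been measured in this assay. It differs from compound 3 in one place: methoxy in place of hydrogen on an aromatic carbon. Going by the values given here, no measured pair shows such an exchange, so nothing here tells what size or direction to expect. On that basis the step from compound 3 to compound 4 is expected to be small, a 1.2-fold higher number from compound 3 to compound 4 (0.08 log units; within the scatter), with no clear direction and likely within the scatter. Compound 4 is therefore estimated at 3.5 nM in this assay, within a range of 1.2 nM to 10 nM.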

Compound 4, inhibition constant: 16 nM
Estimate against measurement, compound 4: 4.6-fold (0.66 log units) below; measured number above the stated range.
By their numbers in this assay, from the lowest: compound 3; then compounds 1, 2 and 4 (each within the scatter of the next, the first and the last beyond it).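

In this assay, going by these compounds alone, methoxy in place of hydrogen on this aromatic carbon, ortho to a large group and meta to the 2H-tetrazol-5-yl group, gives a 5.5-fold higher number from compound 3 to compound 4 (0.74 log units; beyond the scatter), and this is the first one-place step. The position is therefore not indifferent to substitution: here, adding methoxy weakens inhibition by more than the scatter. Nothing available bears on the reason for this step.

A single exchange leaves open whether the loss is particular to methoxy or would also appear with a fluorine atom, a hydroxyl or a longer ether such as ethoxy at the same carbon. It also leaves open whether methoxy would give a step of similar size and direction on another carbon of this ring.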